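Methoxy for Methyl on a Shared Anticonvulsant Core

The compounds below may be only part of what the source reports. "The series", "measured", "known", "first", "only" and "open" are said of these compounds alone.

Of the compounds shown here, two built on a shared core have been tested in a functional assay on the whole organism (strain albino) with Mus musculus as the target, in the maximal electroshock model, with a stated time of 4 h; on this read-out higher numbers stand for an effect only at larger amounts of compound and lower numbers for an effect already at smaller amounts. Compound 1 `COc1ccc(Nc2nnc(Nc3nc(-c4ccc([N+](=O)[O-])cc4)cs3)s2)cc1` gives 30 mg/kg in this assay. Compound 2 `Cc1ccc(Nc2nnc(Nc3nc(-c4ccccc4)cs3)s2)cc1` gives 100 mg/kg in this assay, the highest of the two numbers; its nearest neighbour is compound 1, whose number is lower by a margin beyond the usual scatter. Compound 1 and compound 2 differ in more than one place, so their two values cannot be traced to any single change.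

Compound 3 `COc1ccc(Nc2nnc(Nc3nc(-c4ccccc4)cs3)s2)cc1` has not yet been measured. It differs from compound 2 in one place: methoxy in place of methyl on an aromatic carbon. Compound 1 also carries the methoxy group, and in this assay compound 1 gives a lower number than compound 2, but compound 1 carries a further change as well, so that comparison gives only a hint of direction. A step toward a lower number is expected, though a step no larger than the scatter would not surprise. The step expected is a 2.0-fold lower number from compound 2 to compound 3 (0.30 log units; within the scatter). Compound 3 is therefore expected to give about 50 mg/kg in this assay, within a range from 20 mg/kg to 150 mg/kg.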

Compound 3, minimum effective dose: 100 mg/kg
Compound 3: middle estimate off by 2.0-fold (0.30 log units), on the low side; low and high end bracket the measured number.
By their numbers in this assay, from the lowest: compound 1; then compounds 2 and 3 (each within the scatter of the next).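

In this assay, methoxy in place of methyl on an aromatic carbon, para to a large group, gives no change at the digits printed from compound 2 to compound 3 (within the scatter), so at this position the two groups cannot be told apart by this read-out. The earlier hint about methoxy therefore falls away: with the 4-methylphenyl to 4-methoxyphenyl change accounting for no visible difference, the gap seen earlier now finds its single-change comparison in the other ring, where hydrogen in place of nitro on an aromatic carbon gives a 3.3-fold higher number from compound 1 to compound 3 (0.52 log units; beyond the scatter), a modest step that lies beyond the scatter. No measurement at hand explains either result.

As far as these compounds go, what remains open is whether this position tolerates other groups equally well, since methyl and methoxy are only two options and a chlorine atom, an amine or a longer chain at the same carbon could behave quite differently. From the compounds shown here alone, it is also open whether the nitro step would hold with methyl in place of methoxy, and whether an amine or a carboxylic acid on that other ring would give a similar number.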